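Pyridyl Amide Swap on a Phthalimide-Bearing Anilide Core

The compounds below may be only part of what the source reports. "The series", "measured", "known", "first", "only" and "open" are said of these compounds alone.

Compounds measured in an assay on CHO cells for positive allosteric modulation of metabotropic glutamate receptor 5 (Homo sapiens), read by FLIPR; a higher number here means that more compound is needed for the effect, a lower number that less compound is needed:
compound 1 `COc1cccc(C(=O)Nc2ccc(Cl)cc2CN2C(=O)c3ccccc3C2=O)c1`, 1500 nM
compound 2 `Cc1ccc2c(c1C)C(=O)N(Cc1cc(Br)ccc1NC(=O)c1ccccn1)C2=O`, > 100000 nM

Compound 1 holds the only actual number shown in this assay. Compound 2 reaches only a limit of this assay, (the limit of > 100000 nM in this assay, at which 1 of the 2 values shown sits), so no number is known for it. Compound 3 `O=C(Nc1ccc(Cl)cc1CN1C(=O)c2ccccc2C1=O)c1cccnc1` differs from compound 1 in one place: pyridin-3-yl in place of 3-methoxyphenyl on a carbonyl carbon. Within the data shown here, no measured pair follows this exact change, so the size of the step in this assay is open; a modest loss is expected, estimated as a 2.7-fold higher number from compound 1 to compound 3 (0.43 log units; beyond the scatter). Compound 3 is therefore expected to give about 4000 nM, within 1000 nM to 20000 nM.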

Compound 3, half-maximal effective concentration: 35000 nM
Estimate against measurement, compound 3: 8.8-fold (0.94 log units) below, outside the stated range (above it).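

In this assay, the group on the carbonyl carbon proves a sensitive place on the shared core: pyridin-3-yl in place of 3-methoxyphenyl gives a 23-fold higher number from compound 1 to compound 3 (1.37 log units; beyond the scatter). Compound 2 differs from compound 1 in more than one place and reaches only a limit, so it could not show this. Nothing shown accounts for the size of this step.

From the compounds shown here alone, whether the ring nitrogen or the absent methoxy group drives the step stays open. So does whether a methoxy-bearing pyridine or a plain phenyl at this carbonyl carbon would restore the number of compound 1.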